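The source may report more compounds than this note shows. Statements on the series, on what has been measured and on what is new or still open speak of the compounds shown alone.

Of the compounds shown here, three have been measured in an assay on isolated protein for inhibition of serine/threonine-protein kinase PLK2 (Homo sapiens), read by TR-FRET, with a stated time of 60 min; a lower number here means a stronger inhibitor, a higher number a weaker inhibitor. Compound 1 `CC(C)N1c2nc(-n3ccnc3-c3ccc(F)cc3)ncc2N(C)C(=O)C1(C)C` gives 2710 nM, compound 2 `CC[C@@H]1C(=O)N(C)c2cnc(-n3ccnc3-c3ccccc3)nc2N1[C@H]1CCOC1` gives 8 nM, and compound 3 `CCC1C(=O)N(C)c2cnc(-n3ccnc3-c3ccc(F)cc3)nc2N1C1CCC(F)(F)C1` gives 13 nM. Compound 3 stands second highest of the three numbers: its nearest neighbour is compound 2, within the scatter, and its furthest is compound 1, whose number is far higher and beyond the scatter.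

Compound 4 `CCC1C(=O)N(C)c2cnc(-n3ccnc3-c3ccc(F)cc3)nc2N1c1ccc(F)cc1` has not yet been measured. It differs from compound 3 in one place: 4-fluorophenyl in place of 3,3-difluorocyclopentyl on a nitrogen on an aromatic ring in a ring. Going by the values given here, no single-change step among the measured compounds touches this position, so the data give no direct precedent for the replacement.

For compound 4 the expected step is a 1.5-fold higher number from compound 3 to compound 4 (0.19 log units; within the scatter), and this expectation is only a working guess: small, in the weaker direction, and not clearly beyond the scatter. Compound 4 is therefore estimated at 20 nM, within a range from 6 nM to 80 nM.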

Compound 4, half-maximal inhibitory concentration: 15 nM
For compound 4 the middle estimate is 1.3-fold (0.12 log units) above the measured one, and the stated range covers the measured number.
By their numbers in this assay, from the lowest: compounds 2, 3 and 4 (each within the scatter of the next); then compound 1.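

In this assay, 4-fluorophenyl in place of 3,3-difluorocyclopentyl on this nitrogen gives a 1.2-fold higher number from compound 3 to compound 4 (0.06 log units; within the scatter). At this position, then, a six-membered aromatic ring of carbon only and a five-membered non-aromatic ring of carbon only give numbers within the scatter of each other. No measurement available here offers an explanation for this result.

From the compounds shown here alone, it remains open whether an open-chain group such as n-butyl on this nitrogen would give a similar number. Also open, going by these compounds, is whether an amine or a carboxylic acid in place of the fluorine of 4-fluorophenyl would do so.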